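The compounds below may be only part of what the source reports. "The series", "measured", "known", "first", "only" and "open" are said of these compounds alone.

Values in a functional assay on SMMC-7721 cells (Homo sapiens) for antiproliferative activity, read by MTT assay, with a stated time of 48 h; a higher number here means a weaker inhibitor, a lower number a stronger inhibitor:
- Compound 1 `Cn1cc(C2=C(c3nn(CCCn4cncn4)c4ncccc34)C(=O)NC2=O)c2ccccc21`: > 100000 nM, a limit.
- Compound 2 `Cn1cc(C2=C(c3nn(CCCN4CCCCC4)c4ncccc34)C(=O)N(c3ccccc3)C2=O)c2ccccc21`: 3050 nM.
- Compound 3 `Cn1cc(C2=C(c3nn(CCCN4CCCCC4)c4ncccc34)C(=O)N(c3ccc(Cl)cc3)C2=O)c2ccccc21`: > 100000 nM, a limit.

Compound 3 has no exact number and sits at the limit of > 100000 nM in this assay, at which 2 of the 3 values shown sit. Compound 4 `Cn1cc(C2=C(c3nn(CCCN4CCCCC4)c4ncccc34)C(=O)N(c3cccc4ccccc34)C2=O)c2ccccc21` carries naphthalen-1-yl in place of 4-chlorophenyl on an amide-type nitrogen in a ring. Among the compounds with values here, one measured step bears on this, and it involves the group on that same nitrogen: an at least 32-fold higher number from compound 2 to compound 3 (1.51 log units; beyond the scatter). That large step, beyond the scatter, came from chloro in place of hydrogen on an aromatic carbon. Compound 4 has no chloro, so a sizeable move toward a lower number is expected, although it may also remain at the limit. The estimated step is an at least 5.0-fold lower number from compound 3 to compound 4 (0.69 log units; beyond the scatter). For compound 4 the estimated value is 20000 nM, with an expected range from 3000 nM to 100000 nM.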

Compound 4, half-maximal inhibitory concentration: 220 nM
Compound 4: middle estimate off by 91-fold (1.96 log units), on the high side; the measured number lies below the stated range.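

The group on the amide-type nitrogen can lower the number as well as raise it: in this assay, naphthalen-1-yl in place of 4-chlorophenyl gives an at least 450-fold lower number from compound 3 to compound 4 (2.65 log units; beyond the scatter). Naphthalen-1-yl in place of phenyl gives a 14-fold lower number from compound 2 to compound 4 (1.14 log units; beyond the scatter), so two six-membered aromatic rings at this position do better here than the single ring of phenyl. The value of compound 3 is a limit, not a number: the limit of > 100000 nM in this assay, at which 2 of the 4 values shown sit.

Still open, on these data alone, is whether naphthalen-2-yl or benzyl on this nitrogen would give a similarly low number. Whether a methyl or methoxy group on the phenyl ring would behave like chloro is also unknown.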